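Swapping the Ring on a Sulfur-Linked Side Chain

The source may hold more compounds than are shown below. What is called first, only, known or untested is meant among the compounds shown, and "the series" means these compounds.

Compound 1 `Cc1cc(=O)oc2cc(SCc3ccccn3)ccc12` was tested in a functional assay on DU-145 cells (Homo sapiens) for antiproliferative activity, read by sulforhodamine B assay, with a stated time of 72 h; a lower number here means a stronger inhibitor of growth, a higher number a weaker inhibitor of growth. In this assay compound 1 gives > 35200 nM, which is a limit of the assay rather than a number. Compound 2 `Cc1cc(=O)oc2cc(SCc3cccc(C(F)(F)F)c3)ccc12` was examined the same way. In this assay compound 2 gives > 28500 nM, again a limit and not a number. Compound 1 therefore stands nowhere definite among the numbers shown: both values sit at limits, the limit of > 35200 nM in this assay, at which 1 of the 2 values shown sits, and (the limit of > 28500 nM in this assay, at which 1 of the 2 values shown sits). Compound 3 `Cc1cccc(CSc2ccc3c(C)cc(=O)oc3c2)c1` has not yet been measured. It differs from compound 1 in one place: 3-methylphenyl in place of pyridin-2-yl on a saturated chain carbon bound to a sulfur. For the measured compounds named here, no measured step connects two compounds here, so any expectation rests only on the two limits. Compound 2 already carries a ring of carbon only on that chain carbon and still gives > 28500 nM, a limit. The expected step is a step that the limit leaves unreadable from compound 1 to compound 3, none beyond the scatter. Compound 3 is estimated at 40000 nM, within 12000 nM to 120000 nM, and this assay will most likely again report only a limit.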

Compound 3, concentration for 50% growth inhibition: > 33700 nM
Compound 3 gave a limit, no number; the forecaster's own chance of this, stated with the estimate: 80%; the middle value does not contradict the limit.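

Compound 1, compound 2 and compound 3 all give only limits in this assay, so no step can be read between compound 3 and either of the other two. The compounds shown leave open how these rings on the chain carbon compare, and whether any such ring would give an actual number.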